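A few compounds are considered here, and "the series" means these few. Any claim that something is new, unique, unknown or untested is made for them only; others in the source may bear on it.

Compound 2 `Cc1ccccc1COc1ccc(N2CCC[C@H]2CC(=O)O)cc1` belongs to a small group of acids built on one shared core, and on the numbers available it has no position at all: in an assay on HEK293 cells for binding affinity to Free fatty acid receptor 1 (Homo sapiens), read by scintillation counting and radioligand binding, with a stated time of 1 h (on this read-out higher numbers stand for weaker inhibition and lower numbers for stronger inhibition), compound 2 is recorded only as "not determined" (no result reported), and the same is true of its close relative compound 3 `Cc1ccccc1COc1ccc(N2CCC[C@H]2CC(=O)O)cc1C`, which stands as "not determined" (no result reported). Going by the values given here, the one member of the group with a real number is compound 1 `O=C(O)C[C@@H]1CCCN1c1ccc(OCc2ccc(Cl)cc2Cl)cc1`, which in this assay gives 890 nM; that value is the only anchor for anything said about the others.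

The step from compound 2 to compound 4 `O=C(O)C[C@@H]1CCCN1c1ccc(Oc2ccccc2)cc1` replaces the whole side group on the ether oxygen: phenyl in place of 2-methylbenzyl on an oxygen on an aromatic ring. The group that enters is smaller than the group that leaves, and the ring now sits directly on the oxygen rather than one carbon further out.

Among the compounds with values here, with no measured pair to lean on, the size of this step in this assay can only be guessed, and the guess is for a shift toward weaker binding, larger than the usual scatter. Compound 4 is therefore expected to give about 3000 nM, within a range from 800 nM to 12000 nM.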

Compound 4, inhibition constant: 6500 nM
The estimate for compound 4 lay 2.2-fold (0.34 log units) below the measured number; the measured number falls inside the stated range.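

Going by these compounds alone, compound 2 has no single number in this assay and so compound 4 at 6500 nM gives no step that can be read. The compounds shown leave open how far replacing 2-methylbenzyl with phenyl on an oxygen on an aromatic ring shifts binding. No measured finding bears on this result.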